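The source may hold more compounds than are shown below. What is called first, only, known or untested is meant among the compounds shown, and "the series" means these compounds.

Measured compounds:
- compound 1 `CCCCCc1c(C(C)C)nc(C(C)C)c(CO)c1-c1cccc(C)c1` gives 46% in an assay on CHO cells for inhibition of Glucagon receptor (Homo sapiens), tested at 20 uM; a higher number here means more inhibition at the concentration tested (going by the name of the read-out), a lower number less inhibition
- compound 2 `CCCCCc1c(C(C)C)nc(C(C)C)c(CO)c1-c1ccc2c(c1)CCCC2` gives 37%
- compound 3 `CCCCCc1c(C(C)C)nc(C(C)C)c(CO)c1-c1cccc(C(F)(F)F)c1` gives 25%

Among these three, compound 1 stands highest, though its gap to compound 2 lies within the usual scatter of this measurement, so the two cannot be ordered; only compound 3 is clearly lower. Compound 4 `CCCCCc1c(C(C)C)nc(C(C)C)c(CO)c1-c1ccccc1OC` keeps the shared core of compound 1 and changes the attached aryl ring: 2-methoxyphenyl in place of 3-methylphenyl on an aromatic carbon.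

Among the measured compounds shown here, no measured step shows this exact change. For the measured compounds named here, the one step that touches the same ring, a number 21 percentage points lower from compound 1 to compound 3 (beyond the scatter), shows that swapping a substituent on this ring can lower the number modestly. Compound 2, with a different shape of that ring, sits within the scatter of compound 1. Taken together, changes here so far have left the number where it was or pulled it down, never up. A small downward step, or none beyond the scatter, is therefore expected: a number 10 percentage points lower from compound 1 to compound 4 (within the scatter).

Compound 4 is thus estimated at 36%, within a range of 16% to 56%.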

Compound 4, a percentage reported as inhibition, at one concentration (the size of the read-out at that concentration, not a potency): 27%
For compound 4 the middle estimate is 9 percentage points above the measured one; measured number inside the range.
By their numbers in this assay, from the lowest: compounds 3, 4, 2 and 1 (each within the scatter of the next, the first and the last beyond it).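

The change to 2-methoxyphenyl gives a number 19 percentage points lower from compound 1 to compound 4 (beyond the scatter), so this position on the shared core has now lost ground to a second substituted ring, after the trifluoromethyl ring of compound 3. The entering ring brings an oxygen and a hydrogen-bond acceptor that 3-methylphenyl lacks, and among compounds 1 to 4 none of these ring changes has raised the number, though compound 2 stays within the scatter of compound 1. Nothing shown here explains the lower number at this position.

The group and its place on the ring change together in this step, and no compound shown separates the two. Also open, going by these compounds, is how a ring carrying an amine or a carboxylic acid would read in this assay at this same position.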